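A Chlorophenyl Group Returns to the Ring Nitrogen

The source may hold more compounds than are shown below. What is called first, only, known or untested is meant among the compounds shown, and "the series" means these compounds.

Compound 3 `O=C1NC(=O)C2(CSC3=C2C(=O)c2ncccc2C3=O)N1` carries a hydrogen on the ring nitrogen where compounds 1 and 2 carry an aryl group. In a functional assay on HeLa cells (Homo sapiens) for antiproliferative activity, read by MTT assay, with a stated time of 96 h (on this read-out higher numbers stand for weaker inhibition and lower numbers for stronger inhibition), compound 3 gives 150 nM, the highest of the three numbers shown. Compound 1 `CCCc1ccc(N2C(=O)NC3(CSC4=C3C(=O)c3ncccc3C4=O)C2=O)cc1` gives 5 nM in this assay, and compound 2 `COc1ccc(N2C(=O)NC3(CSC4=C3C(=O)c3ncccc3C4=O)C2=O)cc1` gives 1 nM. The steps to compound 3 are both large: a 30-fold higher number from compound 1 to compound 3 (1.48 log units; beyond the scatter) and a 150-fold higher number from compound 2 to compound 3 (2.18 log units; beyond the scatter). Between the two aryl compounds the step is smaller, a 5.0-fold lower number from compound 1 to compound 2 (0.70 log units; beyond the scatter).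

Compound 4 `O=C1C2=C(C(=O)c3ncccc31)C1(CS2)NC(=O)N(c2ccc(Cl)cc2)C1=O` differs from compound 3 in one place: 4-chlorophenyl in place of hydrogen on an amide-type nitrogen in a ring. This change reverses the direction of the two steps that removed an aryl group, so both bear on it. Those steps were large and pointed the same way, and so a large step downward is expected for compound 4 in this assay. Going by the values given here, nothing among the measured compounds tells how a chlorine substituent on the aryl ring compares with propyl or methoxy, so the size is taken between the two measured steps. The number for compound 4 is therefore estimated at 3 nM in this assay, with a range from 1 nM to 12 nM, which corresponds to an expected step of a 50-fold lower number from compound 3 to compound 4 (1.70 log units; beyond the scatter).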

Compound 4, half-maximal inhibitory concentration: 2 nM
Beside the measured number, compound 4's estimate is 1.5-fold (0.18 log units) above it; the range from low to high includes it.
By their numbers in this assay, from the lowest: compounds 2 and 4 (each within the scatter of the next); then compound 1; then compound 3.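

Putting 4-chlorophenyl on the amide-type nitrogen in a ring gives a 75-fold lower number from compound 3 to compound 4 (1.88 log units; beyond the scatter) in this assay, so a large step at this position now holds for three different aryl groups and no longer rests on propyl and methoxy alone. The substituent on the aryl ring has a smaller and uneven effect: chloro in place of methoxy gives a 2.0-fold higher number from compound 2 to compound 4 (0.30 log units; within the scatter), which stays within the scatter and leaves the two compounds indistinguishable, whereas chloro in place of propyl gives a 2.5-fold lower number from compound 1 to compound 4 (0.40 log units; beyond the scatter), a modest step beyond it. Nothing measured here explains how the aryl group or its substituent produces these differences.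

The compounds shown leave open whether an aromatic ring is needed on this nitrogen at all, since all three groups that give low numbers are substituted phenyl rings, and a benzyl group or a plain butyl chain would test that. They also leave open how far the substituent on the ring can vary, as neither an amine nor a carboxylic acid in place of the chloro appears among them.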